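The source may report more compounds than this note shows. Statements on the series, on what has been measured and on what is new or still open speak of the compounds shown alone.

Measured in a functional assay on K562 cells (Homo sapiens) for antiproliferative activity, read by MTT assay, with a stated time of 5 days; on this read-out higher numbers stand for weaker inhibition and lower numbers for stronger inhibition:
- compound 1 `COc1ccc(C(=Cc2ccc(OC)c([N+](=O)[O-])c2)C(=O)c2cc(OC)c(OC)c(OC)c2)cc1`: 2660000 nM
- compound 2 `COc1ccc(/C=C(/C(=O)c2cc(OC)c(OC)c(OC)c2)c2ccc(OC)cc2OC)cc1`: 90000 nM
- compound 3 `COc1ccc(/C=C(/C(=O)c2cc(OC)c(OC)c(OC)c2)c2ccccc2O)cc1O`: 49000 nM

Compound 1 has the highest number of the three, which makes it the weakest inhibitor here, and its gaps to compound 2 and to compound 3 both lie beyond the scatter. The unmeasured compound 4 `COc1ccc(C=C(C(=O)c2cc(OC)c(OC)c(OC)c2)c2ccc(C)cc2)cc1[N+](=O)[O-]` keeps the core of compound 1 but has methyl in place of methoxy on an aromatic carbon, para to a large group: methyl in place of methoxy on an aromatic carbon. The same difference can be read as 4-methoxyphenyl to 4-methylphenyl.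

Going by the values given here, no measured pair shows this change on its own, so any expectation is loose. Compound 2 at 90000 nM and compound 3 at 49000 nM both sit well lower, so a moderate drop in this assay seems likelier than a further rise, although a result within the scatter of compound 1 is also possible. The expected change is a 2.7-fold lower number from compound 1 to compound 4 (0.42 log units; beyond the scatter). For compound 4 the estimated value is 1000000 nM, with an expected range of 150000 nM to 4000000 nM.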

Compound 4, half-maximal inhibitory concentration: 2430000 nM
Estimate against measurement, compound 4: 2.4-fold (0.39 log units) below; the measured number falls inside the stated range.
By their numbers in this assay, from the lowest: compounds 3 and 2 (each within the scatter of the next); then compounds 4 and 1 (each within the scatter of the next).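

In this assay, putting methyl in place of methoxy on an aromatic carbon, para to a large group, gives a step that can be read on its own (a 1.1-fold lower number from compound 1 to compound 4 (0.04 log units; within the scatter)). The earlier compounds shown here offered no such single-place comparison, and this one shows that, with the rest of the core of compound 1 kept, the two groups cannot be told apart at this position. Losing the oxygen atom and its hydrogen-bond acceptor therefore leaves no visible mark on this read-out, and nothing measured here offers an explanation for that.

Still open, going by these compounds, is whether other groups at this position, such as an amine, a carboxylic acid or a longer chain like ethoxy, would move the number. It is also unknown whether the same swap would stay as silent on a core without the nitro group.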